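Ortho-halogen swap on the shared core

This account rests on a few compounds, and the source may have more. Where it says the series, first, only, none or still open, it means among the compounds named here.

Measured so far:
compound 1, `Cc1nn(-c2ccccc2Cl)c2c1C(c1ccc(Oc3ccccc3)cc1)SC(C)C(=O)N2`: 2700 nM
compound 2, `Cc1nn(-c2ccccc2C(C)C)c2c1[C@@H](c1ccc(Oc3ccccc3)cc1)S[C@@H](C)C(=O)N2`: 1900 nM

Both compounds were characterised in an assay on isolated protein for agonist activity at Bile acid receptor (Homo sapiens), read by AlphaScreen, with a stated time of 30 min; on this read-out lower numbers stand for an effect already at smaller amounts and higher numbers for an effect only at larger amounts of compound. Compound 1 gives 2700 nM in this assay, and compound 2 gives 1900 nM; the two numbers lie within the usual scatter of one another, so nothing separates them. Compound 1 is the reference for the next compound.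

Compound 3, `Cc1nn(-c2ccccc2Br)c2c1C(c1ccc(Oc3ccccc3)cc1)SC(C)C(=O)N2`, has not yet been measured in this assay. It differs from compound 1 by bromo in place of chloro on an aromatic carbon, with no change in donors, acceptors or charge. For the measured compounds named here, no measured pair in this set shows the effect of such a swap, and the one comparison available, compound 1 against compound 2, covers a different part of the molecule and stays within the scatter.

On that basis the step from compound 1 to compound 3 is expected to be a 1.2-fold lower number from compound 1 to compound 3 (0.07 log units; within the scatter), nothing beyond the scatter in either direction. Compound 3 is therefore estimated at 2300 nM, with a range from 900 nM to 5500 nM.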

Compound 3, half-maximal effective concentration: 1800 nM
The estimate for compound 3 lay 1.3-fold (0.11 log units) above the measured number, and the stated range covers the measured number.
By their numbers in this assay, from the lowest: compounds 3, 2 and 1 (each within the scatter of the next).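

Bromo in place of chloro on the aromatic carbon ortho to a large group gives a 1.5-fold lower number from compound 1 to compound 3 (0.18 log units; within the scatter) in this assay, the first single-place step in the series. This position therefore accepts the larger halogen without a shift that can be told from the scatter, although one swap between two halogens does not define the range of groups allowed there. No measurement bears on why the step is this small, so the result stands without an explanation.

Still open, as far as these compounds go, is whether a group of another kind at this place, such as an amine, a carboxylic acid or a methoxy group, would move the number beyond the scatter. Fluoro at the same carbon, or a hydrogen in place of the halogen, would show whether a halogen is needed there at all.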